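Hydroxy(sulfo)methyl in Place of Formyl: Expected Cytotoxicity

A few compounds are considered here, and "the series" means these few. Any claim that something is new, unique, unknown or untested is made for them only; others in the source may bear on it.

Compound 1, `CC(C)C[C@H](NC(=O)OC1CCC(C)(C)CC1)C(=O)N[C@@H](C[C@@H]1CCNC1=O)C(O)S(=O)(=O)O`: in an ADME assay on HEK-293T cells (Homo sapiens) for cytotoxicity, with a stated time of 72 h (on this read-out higher numbers stand for lower toxicity in this test and lower numbers for higher toxicity in this test), compound 1 gives > 100000 nM, which is a limit of the assay rather than a number.
Compound 2, `CC(C)C[C@H](NC(=O)OCc1cccc(F)c1)C(=O)N[C@H](C=O)C[C@@H]1CCNC1=O`: in this assay compound 2 gives > 100000 nM, again a limit of the assay.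

Within the data shown here, both results sit at the limit of > 100000 nM in this assay, at which 2 of the 2 values shown sit, so for compound 2 only a limit is known, and the one further value shown is a limit as well; the two compounds cannot be placed in any order relative to each other on these numbers.

Compound 3, `CC(C)C[C@H](NC(=O)OCc1cccc(F)c1)C(=O)N[C@@H](C[C@@H]1CCNC1=O)C(O)S(=O)(=O)O`, has not yet been tested in this assay. It differs from compound 2 in one place: hydroxy(sulfo)methyl in place of formyl on a saturated chain carbon bound to an amide-type nitrogen and a saturated chain carbon. Among the measured compounds shown here, no step between two measured compounds is available to calibrate this change. Compound 1 already carries the hydroxy(sulfo)methyl group and gives > 100000 nM, a limit, in this assay. Compound 3 is therefore expected to remain at the assay limit, the estimated step of a number no higher from compound 2 to compound 3 (the limit leaves the size open) being none beyond the scatter. For compound 3 the expected value is 100000 nM, in the range 50000 nM to 300000 nM.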

Compound 3, half-maximal cytotoxic concentration: > 100000 nM
Compound 3 ended at the assay's limit; the forecaster's own chance of this, stated with the estimate: 85%; the middle value lies on the limit itself.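

Compound 1, compound 2 and compound 3 all sit at the same limit of the assay, which is not a number, so no step can be read from compound 2 to compound 3 or from compound 1 to compound 3: the limit of > 100000 nM in this assay, at which 3 of the 3 values shown sit.

The compounds shown leave open where the true value of each lies beyond that limit, and whether hydroxy(sulfo)methyl in place of formyl alters the result in this assay at all.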